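Moving a Carboxyl Group on a Bromoalkyl Amide

This account rests on a few compounds, and the source may have more. Where it says the series, first, only, none or still open, it means among the compounds named here.

compound 1 `CCCCCCCCCCOc1cccc(OCCCCCC(=O)N(Cc2ccc(C(=O)O)cc2)c2cccc(C(=O)O)c2)c1` in an assay on isolated protein for binding affinity to E-selectin (Homo sapiens), read by ELISA, tested at 100 uM; on this read-out higher numbers stand for more inhibition at the one concentration tested (going by the name of the read-out) and lower numbers for less inhibition: 42%
compound 2 `O=C(O)c1ccc(N(C(=O)CCCCCBr)c2cccc(C(=O)O)c2)cc1`: "not determined" (no result reported)
compound 3 `CCCCCCCCCCOc1cc(OCCCCCCCCCC)cc(OCCCCCCN(Cc2ccc(C(=O)O)cc2)c2ccc(C(=O)O)cc2)c1`: "not determined" (no result reported)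

Only compound 1 has a number in this assay; compound 2 stands without one, and compound 3 likewise has no result. Compound 4 `O=C(O)c1ccc(N(C(=O)CCCCCBr)c2ccc(C(=O)O)cc2)cc1` differs from compound 2 in one place: 4-carboxyphenyl in place of 3-carboxyphenyl on an amide-type nitrogen. Going by the values given here, no measured pair shows this change, and compound 2 gives no value to anchor it, so the step can only be guessed. Compound 2 and compound 4 share the whole remainder of the structure, and a step of no more than the usual scatter, in either direction, is expected. Compound 1 is the only reference for the scale. Compound 4 is expected to give about 15% in this assay, in the range 0% to 40%.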

Compound 4, a percentage reported as inhibition, at one concentration (the size of the read-out at that concentration, not a potency): 5%
Estimate against measurement, compound 4: 10 percentage points above; low and high end bracket the measured number.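

Going by these compounds alone, compound 2 carries no number in this assay, so compound 4 at 5% yields no step that can be read. Whether 4-carboxyphenyl in place of 3-carboxyphenyl changes inhibition stays open, and nothing shown explains this value.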